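Ethyl to propyl in the series

A few compounds are considered here, and "the series" means these few. Any claim that something is new, unique, unknown or untested is made for them only; others in the source may bear on it.

Measured in a functional assay (mitochondria) for inhibition, with Rattus norvegicus as the target; a higher number here means a weaker inhibitor, a lower number a stronger inhibitor:
compound 1 `Cc1nc2cc(OC[C@H](O)CN3CCN(CC(=O)Nc4c(C)cccc4C)C[C@@H]3C)ccc2s1` gives 200 nM
compound 2 `CCc1nc2cc(OCC(O)CN3CCN(CC(=O)Nc4c(C)cccc4C)CC3)ccc2s1` gives 13000 nM

Compound 2 holds the higher number of the two, and its gap to compound 1 lies beyond the scatter. A weak inhibitor is therefore the starting point for the next step. Compound 3 `CCCc1nc2cc(OCC(O)CN3CCN(CC(=O)Nc4c(C)cccc4C)CC3)ccc2s1` follows from compound 2 by a single change (methyl in place of hydrogen on a saturated chain carbon, two bonds along the chain from an aromatic carbon): methyl in place of hydrogen on a saturated chain carbon, two bonds along the chain from an aromatic carbon, which also reads ethyl to propyl. Among the compounds with values here, no pair of measured compounds differs in only one place, so the data give no direct size for this change. The step expected is a 1.3-fold lower number from compound 2 to compound 3 (0.11 log units; within the scatter) in this assay and no shift beyond the scatter is estimated. Compound 3 is expected at 10000 nM (estimated range 3000 nM to 30000 nM).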

Compound 3, half-maximal inhibitory concentration: 20000 nM
Compound 3: the middle estimate sits 2.0-fold (0.30 log units) below what was measured; the range from low to high includes it.
By their numbers in this assay, from the lowest: compound 1; then compounds 2 and 3 (each within the scatter of the next).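

In this assay the change from ethyl to propyl gives a 1.5-fold higher number from compound 2 to compound 3 (0.19 log units; within the scatter), which is a direct size for methyl in place of hydrogen on a saturated chain carbon, two bonds along the chain from an aromatic carbon. On this evidence, the two chain lengths are not separated at this position on the core of compound 2, and compounds 2 and 3 stand level in this read-out. Nothing available offers an explanation for this result.

Open, as far as these compounds go, is whether a longer chain such as butyl, or an amine or a carboxylic acid in place of the propyl group, would move the number beyond the scatter. Also open, from the compounds shown here alone, is what this same change does on the core of compound 1, which differs from compound 2 in more than one place.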